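The compounds below may be only part of what the source reports. "The series", "measured", "known", "first", "only" and "open" are said of these compounds alone.

Measured compounds:
- Compound 1 `CC(C)n1c(S)nnc1Sc1nnc(-c2ccccc2)n1-c1ccccc1`: "not determined" (no result reported)
- Compound 2 `Fc1ccc(-n2c(S)nnc2Sc2nnc(-c3ccccc3)n2-c2ccccc2)cc1`: 29700 nM
- Compound 3 `CC(C)n1c(S)nnc1CSc1nnc(-c2ccccc2)n1-c1ccccc1`: "not determined" (no result reported)

Within the data shown here, in a functional assay on MDA-MB-231 cells (Homo sapiens) for inhibition, read by MTT assay, with a stated time of 48 h (on this read-out lower numbers stand for stronger inhibition and higher numbers for weaker inhibition), compound 2 gives 29700 nM and is the only one of the three with a number; compound 1 and compound 3 have no result, so no step between measured compounds can be drawn. Compound 4 `Sc1nnc(Sc2nnc(-c3ccccc3)n2-c2ccccc2)n1-c1ccccc1` has not been measured yet. It differs from compound 2 in one place: hydrogen in place of fluoro on an aromatic carbon, which cuts one bond further out as 4-fluorophenyl to phenyl. Among the measured compounds shown here, with no measured step to rest on, the expected change from compound 2 to compound 4 in this assay is a 1.0-fold higher number from compound 2 to compound 4 (0.00 log units; within the scatter), small and within the usual scatter, in no clear direction. Compound 4 is therefore estimated at 30000 nM, with a range from 12000 nM to 75000 nM.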

Compound 4, half-maximal inhibitory concentration: 34600 nM
Compound 4: middle estimate off by 1.2-fold (0.06 log units), on the low side; the range from low to high includes it.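

In this assay, replacing fluoro with hydrogen on the aromatic ring gives a 1.2-fold higher number from compound 2 to compound 4 (0.07 log units; within the scatter). Among these compounds, this is the first measured comparison at this position, and it shows that this change, which turns 4-fluorophenyl into phenyl, does not separate the two compounds. Nothing available explains this result.

Going by these compounds, whether an amine, a carboxylic acid or a longer chain at this position would shift the number remains open. So does whether the same swap would make as little difference elsewhere on the molecule.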